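Replacing Dimethylpentyl with Phenylcyclopropyl on the Side Chain

The source may hold more compounds than are shown below. What is called first, only, known or untested is meant among the compounds shown, and "the series" means these compounds.

compound 1: `O=C(O)CCCSCCN1C(=O)CCC[C@@H]1/C=C/[C@@H](O)CCC1CCC1`, 34 nM
compound 2: `CCCCC(C)(C)C(O)/C=C/[C@H]1CCCC(=O)N1CCSCCCC(=O)O`, 290 nM

In a functional assay with prostaglandin E2 receptor EP4 subtype (Homo sapiens) as the target (a lower number here means that less compound is needed, a higher number that more compound is needed for the effect), compound 2 gives 290 nM, the highest of the two numbers; compound 1 gives 34 nM. Compound 3 `O=C(O)CCCSCCN1C(=O)CCC[C@@H]1/C=C/C(O)C1(c2ccccc2)CC1` is not yet measured and differs from compound 2 by 1-phenylcyclopropyl in place of 1,1-dimethylpentyl on a saturated chain carbon bound to a double-bonded chain carbon and an oxygen on a saturated carbon. Within the data shown here, the one measured step at this position, an 8.5-fold higher number from compound 1 to compound 2 (0.93 log units; beyond the scatter), moved from a ring-bearing group to an open chain and raised the number. Among the measured compounds shown here, compound 3 reintroduces rings at the same place, so a lower number is expected, though the new group is not the one of compound 1. Compound 3 is therefore estimated at 70 nM, between 18 nM and 280 nM, an expected step of a 4.1-fold lower number from compound 2 to compound 3 (0.62 log units; beyond the scatter).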

Compound 3, half-maximal effective concentration: 260 nM
The estimate for compound 3 lay 3.7-fold (0.57 log units) below the measured number, within the range that was stated.
By their numbers in this assay, from the lowest: compound 1; then compounds 3 and 2 (each within the scatter of the next).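

In this assay, 1-phenylcyclopropyl in place of 1,1-dimethylpentyl gives a 1.1-fold lower number from compound 2 to compound 3 (0.05 log units; within the scatter) and so separates the two groups by no more than the scatter. Carrying rings at this place is therefore not enough by itself to reach the number of compound 1 (34 nM) in this series. No evidence offered here bears on this result. The compounds shown leave open whether a fluorine or a methoxy group on the phenyl ring would change the number. They also leave open what a pyridine in place of that phenyl ring would do.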